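Swapping Hydroxy for Dimethylamino: Expected Tolerated Concentration

The compounds below may be only part of what the source reports. "The series", "measured", "known", "first", "only" and "open" are said of these compounds alone.

Compound 1 `CC(/C=N/Nc1ccc([N+](=O)[O-])cc1)=N\NC(=O)c1ccccc1N`: 29800 nM
Compound 2 `CC(/C=N/Nc1ccc([N+](=O)[O-])cc1)=N\NC(=O)c1ccc(Cl)cc1`: 63900 nM
Compound 3 `CC(/C=N/Nc1ccc([N+](=O)[O-])cc1)=N\NC(=O)c1ccc(O)cc1`: 51000 nM

All three share one core and differ only in the aromatic ring on the carbonyl carbon. In an ADME assay on J774 cells (Mus musculus, strain BALB/c) for cytotoxicity, read by resazurin assay, with a stated time of 72 h (a higher number here means that more compound is tolerated, a lower number that less compound is tolerated), compound 3 gives the second highest of the three numbers: a 1.3-fold lower number from compound 2 to compound 3 (0.10 log units; within the scatter), and a 1.7-fold higher number from compound 1 to compound 3 (0.23 log units; within the scatter). Only a 2.1-fold higher number from compound 1 to compound 2 (0.33 log units; beyond the scatter). Compound 4 `CC(/C=N/Nc1ccc([N+](=O)[O-])cc1)=N\NC(=O)c1ccc(N(C)C)cc1` has not been measured; it differs from compound 3 in one place: dimethylamino in place of hydroxy on an aromatic carbon. The step from compound 2 to compound 3 also exchanges a group on an aromatic carbon and stayed within the scatter, and the other two steps were small, so no step beyond the scatter is expected in this assay. Compound 4 is therefore estimated at 50000 nM, ranging from 25000 nM to 100000 nM, which is expected to mean a 1.0-fold lower number from compound 3 to compound 4 (0.01 log units; within the scatter).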

Compound 4, half-maximal cytotoxic concentration: > 100000 nM
Compound 4 was reported as a limit; the forecaster's own chance of this, stated with the estimate: 5%; middle value at least 2.0-fold (0.30 log units) away from the limit.
By their numbers in this assay, from the lowest: compounds 1, 3 and 2 (each within the scatter of the next, the first and the last beyond it). At a limit, above all of these: compound 4.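

Compound 4 gives > 100000 nM in this assay, and this is a limit of the assay, not a number. Dimethylamino on this aromatic carbon is the only group shown to reach that limit, but only one step is certain to lie beyond the scatter: an at least 3.3-fold higher number from compound 1 to compound 4 (0.52 log units; beyond the scatter). The other two, an at least 1.9-fold higher number from compound 3 to compound 4 (0.29 log units; that floor lies within the scatter) and an at least 1.5-fold higher number from compound 2 to compound 4 (0.19 log units; that floor lies within the scatter), may be larger, but their floors alone do not separate dimethylamino from hydroxy or chloro: the limit of > 100000 nM in this assay, at which 1 of the 4 values shown sits.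

Still open, from the compounds shown here alone, is whether a plain amino group or a carboxylic acid on that same aromatic carbon would also reach the limit.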